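This account rests on a few compounds, and the source may have more. Where it says the series, first, only, none or still open, it means among the compounds named here.

Compound 1, `O=C(N/N=C/c1ccc(Br)cc1)Nc1cccc2ccccc12`: 300 mg/kg
Compound 2, `O=C(N/N=C/c1ccc(Cl)cc1)Nc1cccc2ccccc12`: 300 mg/kg
Compound 3, `O=C(N/N=C/c1ccccc1O)Nc1cccc2ccccc12`: 300 mg/kg

These three compounds share one core and differ only in the ring attached to the carbon that carries a double bond to nitrogen. In a functional assay on the whole organism (strain Swiss albino) with Mus musculus as the target, with a stated time of 0.5 h (a lower number here means that less compound is needed, a higher number that more compound is needed for the effect), compound 1 gives 300 mg/kg, compound 2 gives 300 mg/kg and compound 3 gives 300 mg/kg. Compound 3 thus stands level with its two neighbours: the step of no change at the digits printed from compound 1 to compound 3 (within the scatter) and the step of no change at the digits printed from compound 2 to compound 3 (within the scatter) are both flat, as is the step of no change at the digits printed from compound 1 to compound 2 (within the scatter). Among the measured compounds shown here, nothing among the measured compounds has so far moved the minimum effective dose.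

Compound 4, `O=C(N/N=C/c1ccccc1Cl)Nc1cccc2ccccc12`, has not yet been tested. For the measured compounds named here, its single difference from compound 3 is chloro in place of hydroxy on an aromatic carbon.

The closest guides are the steps from compound 1 and compound 2 to compound 3, in which a halogen-bearing ring was exchanged for a hydroxy-bearing ring without any change in dose, and the step from compound 1 to compound 2, in which one halogen replaced another, again with no change. Returning from hydroxy to a halogen is therefore expected to leave the dose where it is, so the expected step of no change at the digits printed from compound 3 to compound 4 (within the scatter) is none beyond the scatter. Compound 4 is estimated at 300 mg/kg, within 150 mg/kg to 600 mg/kg.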

Compound 4, minimum effective dose: 300 mg/kg
Compound 4: the middle estimate sits on the measured number at the digits printed; low and high end bracket the measured number.
By their numbers in this assay, from the lowest: compounds 1, 2, 3 and 4 (each within the scatter of the next).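

In this assay, replacing hydroxy with chloro on an aromatic carbon ortho to a large group gives no change at the digits printed from compound 3 to compound 4 (within the scatter), so the hydrogen-bond donor and acceptor counted on hydroxy can leave this place without any visible effect on the dose. Among the compounds shown here, the result also adds a halogen at this place and so allows the first comparison of one halogen at two places on the ring: 2-chlorophenyl in place of 4-chlorophenyl gives no change at the digits printed from compound 2 to compound 4 (within the scatter), while 2-chlorophenyl in place of 4-bromophenyl gives no change at the digits printed from compound 1 to compound 4 (within the scatter). No measurement is available to explain why these exchanges leave the dose flat.

On these data alone, the ring in these four compounds carries only chloro, bromo or hydroxy, so it remains open what an amine, a carboxylic acid or a longer chain would do at this place. As far as these compounds go, it also remains open whether any change on this ring can move the minimum effective dose, and whether a change elsewhere on the shared core would do so.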